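This account rests on a few compounds, and the source may have more. Where it says the series, first, only, none or still open, it means among the compounds named here.

Measured so far in a functional assay on MCF7 cells (Homo sapiens) for antiproliferative activity, read by MTT assay, with a stated time of 48 h; a lower number here means a stronger inhibitor, a higher number a weaker inhibitor:
- Compound 1 `COc1cccc(-c2nc3cccc(-c4cc(OC)c(OC)c(OC)c4)c3o2)c1`: > 25000 nM (a limit)
- Compound 2 `COc1cc(-c2cccc3nc(-c4cccc(O)c4)oc23)cc(OC)c1OC`: > 25000 nM (a limit)

Compound 2 yields no number in this assay, only the limit > 25000 nM. Both measured compounds sit at the limit of > 25000 nM in this assay, at which 2 of the 2 values shown sit. Among the measured compounds shown here, the one measured step is a step that the two limits leave unreadable from compound 1 to compound 2, and it offers no size to carry forward.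

Compound 3 `COc1cc(-c2nc3cccc(-c4cc(OC)c(OC)c(OC)c4)c3o2)ccc1O` differs from compound 2 in one place: 4-hydroxy-3-methoxyphenyl in place of 3-hydroxyphenyl on an aromatic carbon. The new group is 4-hydroxy-3-methoxyphenyl in place of 3-hydroxyphenyl, on an aromatic carbon of the five-membered aromatic ring of the shared core. With no readable step to build on, no change beyond the scatter is expected in this assay, and compound 3 will probably also report only a limit. The expected step is an at least 1.1-fold lower number from compound 2 to compound 3 (0.05 log units; that floor lies within the scatter), an estimate with little behind it. Compound 3 is estimated at 22000 nM, with an expected range of 8000 nM to 60000 nM.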

Compound 3, half-maximal inhibitory concentration: > 25000 nM
Compound 3 ended at the assay's limit; the forecaster's own chance of this, stated with the estimate: 65%; at least 1.1-fold (0.05 log units) between middle value and limit.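

Compound 1, compound 2 and compound 3 all report only a limit, so no step among them can be read: the limit of > 25000 nM in this assay, at which 3 of the 3 values shown sit.

The compounds shown leave open whether 4-hydroxy-3-methoxyphenyl in place of 3-hydroxyphenyl on the shared core changes the antiproliferative activity at all.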